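A few compounds are considered here, and "the series" means these few. Any claim that something is new, unique, unknown or untested is made for them only; others in the source may bear on it.

Measured compounds:
compound 1 `O=C(Nc1cccc(Br)c1)C(Cl)Cl` 8180 nM
compound 2 `O=C(Nc1cccc([N+](=O)[O-])c1)C(Cl)Cl` 44700 nM
compound 3 `COc1cccc(NC(=O)C(Cl)Cl)c1` 57700 nM

In a functional assay on KB cells (Homo sapiens) for antiproliferative activity, read by MTT assay, with a stated time of 72 h (on this read-out lower numbers stand for stronger inhibition and higher numbers for weaker inhibition), compound 3 gives the highest of the three numbers. Its nearest neighbour is compound 2, and the step of a 1.3-fold higher number from compound 2 to compound 3 (0.11 log units; within the scatter) lies within the scatter, so the two cannot be told apart. The larger gap is to compound 1: the step of a 7.1-fold higher number from compound 1 to compound 3 (0.85 log units; beyond the scatter) is beyond the scatter, as is the step of a 5.5-fold higher number from compound 1 to compound 2 (0.74 log units; beyond the scatter).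

Compound 4 `O=C(Nc1cccc(SC(F)(F)F)c1)C(Cl)Cl` differs from compound 3 in one place: (trifluoromethyl)sulfanyl in place of methoxy on an aromatic carbon. Within the data shown here, none of the measured steps swaps in a (trifluoromethyl)sulfanyl group, so no step bears directly on this change. What the measured steps show is that the identity of the group at this position matters, with compound 1 giving the lowest number and the other two groups giving higher ones.

Compound 4 is therefore expected to fall somewhere between these outcomes, with the step of a 3.8-fold lower number from compound 3 to compound 4 (0.59 log units; beyond the scatter) taken as the estimate. Compound 4 is estimated at 15000 nM in this assay, with a range from 4000 nM to 60000 nM.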

Compound 4, half-maximal inhibitory concentration: 4840 nM
Beside the measured number, compound 4's estimate is 3.1-fold (0.49 log units) above it, within the range that was stated.
By their numbers in this assay, from the lowest: compounds 4 and 1 (each within the scatter of the next); then compounds 2 and 3 (each within the scatter of the next).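

In this assay the (trifluoromethyl)sulfanyl group gives a clear gain over the two weaker groups: the step of a 12-fold lower number from compound 3 to compound 4 (1.08 log units; beyond the scatter) is large, and the step of a 9.2-fold lower number from compound 2 to compound 4 (0.97 log units; beyond the scatter) also lies beyond the scatter. Against bromo there is no such separation, since the step of a 1.7-fold lower number from compound 1 to compound 4 (0.23 log units; within the scatter) lies within the scatter, so bromo is no longer the only group at this position that stands apart from nitro and methoxy. No measurement offered here gives a reason for this grouping.

The compounds shown leave open how an amine, a carboxylic acid or a longer alkyl chain would read at this place on the ring. They also leave open whether the same grouping would hold if the rest of the shared core were changed.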